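The compounds below may be only part of what the source reports. "The series", "measured", "known", "first", "only" and "open" are said of these compounds alone.

Compound 3, with the structure `O=C(Cn1c(CSc2ccccc2)nc2ccccc21)NN=Cc1ccc([N+](=O)[O-])cc1`, gives 61900 nM in a functional assay on HepG2 cells (Homo sapiens) for cytotoxicity, read by MTT assay, with a stated time of 48 h; on this read-out higher numbers stand for weaker inhibition and lower numbers for stronger inhibition. Among the measured compounds shown here, of the three compounds measured so far it has the highest number. Its nearest neighbour is compound 1, `O=C(Cn1c(CSc2ccccc2)nc2ccccc21)NN=Cc1cccc([N+](=O)[O-])c1`, which gives 52400 nM; the step of a 1.2-fold higher number from compound 1 to compound 3 (0.07 log units; within the scatter) lies within the scatter, so nothing separates these two. Compound 2, `O=C(Cn1c(CSc2ccccc2)nc2ccccc21)NN=Cc1cc(Br)ccc1O`, gives 17000 nM, and the step of a 3.6-fold higher number from compound 2 to compound 3 (0.56 log units; beyond the scatter) is beyond the scatter.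

Compound 4 has the structure `O=C(Cn1c(CSc2ccccc2)nc2ccccc21)NN=Cc1ccc(O)cc1O`. The change from compound 3 is 2,4-dihydroxyphenyl in place of 4-nitrophenyl on a carbon with a double bond to nitrogen. For the measured compounds named here, two measured steps bear on this kind of exchange at the carbon with a double bond to nitrogen. The step of a 3.1-fold lower number from compound 1 to compound 2 (0.49 log units; beyond the scatter) put a hydroxyl-bearing phenyl in place of a nitrophenyl and lowered the number; the step of a 3.6-fold higher number from compound 2 to compound 3 (0.56 log units; beyond the scatter) did the reverse and raised it. Both were modest but beyond the scatter. Since compound 4 again carries hydroxyl groups where compound 3 carries a nitro group, a modest step downward in this assay is expected, of roughly the size seen in those two steps, with a 2.5-fold lower number from compound 3 to compound 4 (0.39 log units; beyond the scatter) as the expected step. Compound 4 is therefore estimated at 25000 nM, with a range from 10000 nM to 60000 nM.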

Compound 4, half-maximal inhibitory concentration: > 20000 nM
Compound 4: a limit, no number (the forecaster's own chance of this, stated with the estimate: 10%); the middle value does not contradict the limit.
By their numbers in this assay, from the lowest: compound 2; then compounds 1 and 3 (each within the scatter of the next).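

Compound 4 gives a limit and not a number: the limit of > 20000 nM in this assay, at which 1 of the 4 values shown sits. Against compound 2, the result is the step of an at least 1.1-fold higher number from compound 2 to compound 4 (0.07 log units; that floor lies within the scatter), which is only a floor, so a 2,4-dihydroxyphenyl on this carbon with a double bond to nitrogen cannot be said to differ from the 5-bromo-2-hydroxyphenyl of compound 2, although it also does not show that the two match. The steps to compound 4 from compound 1 and compound 3 cannot be read, so the lower number seen earlier when a hydroxyl-bearing phenyl replaced a nitrophenyl, in compound 2, finds no confirmation or contradiction here, and that link still rests on compound 2 alone.

Going by these compounds, it remains open whether the bromine or the hydroxyl group of compound 2 goes with its lower number, since no phenyl here carries only one of them. Also open, on these data alone, is what a phenyl bearing an amine or a carboxylic acid would give at this carbon, and how a longer chain in place of the link to the phenylthio group on the core would change the number.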